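A few compounds are considered here, and "the series" means these few. Any claim that something is new, unique, unknown or untested is made for them only; others in the source may bear on it.

Compound 1 `COc1cccc(/C=C/C(=O)c2c(OC)cc(OC)cc2OC)c1` and compound 2 `COc1cc(OC)c(C(=O)/C=C/c2ccc(Cl)cc2)c(OC)c1` share one core and differ only in the ring at the far end of the double-bonded chain. In a functional assay on MDA-MB-231 cells (Homo sapiens), read by fluorescence and BrdU incorporation, with a stated time of 48 h, tested at 25 uM (a higher number here means a weaker effect of the compound at the concentration tested, a lower number a stronger effect), compound 1 gives 12%, and compound 2 gives 2.1%. The step of a number 9.9 percentage points lower from compound 1 to compound 2 (within the scatter) lies within the scatter, so the two numbers cannot be ordered; compound 2 simply holds the lower of the two figures so far. Compound 3 `COc1cc(OC)c(C(=O)/C=C/c2ccc(Br)cc2)c(OC)c1` keeps everything in compound 2 except one change: bromo in place of chloro on an aromatic carbon. Within the data shown here, no measured step swaps one halogen for another; the only step available, a number 9.9 percentage points lower from compound 1 to compound 2 (within the scatter), exchanges the whole phenyl group and did not move the read-out beyond the scatter. Nothing therefore points to a shift from this small change. Compound 3 is expected to move by a number 1.9 percentage points higher from compound 2 to compound 3 (within the scatter). The estimate for compound 3 in this assay is 4%, within a range from 0% to 14%.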

Compound 3, a percentage reported as activity, at one concentration (the size of the read-out at that concentration, not a potency): 44%
Beside the measured number, compound 3's estimate is 40 percentage points below it, and the stated range ends below it.
By their numbers in this assay, from the lowest: compounds 2 and 1 (each within the scatter of the next); then compound 3.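

Bromo in place of chloro on an aromatic carbon, para to a large group, is a change of one heavy atom, yet it gives a number 41.9 percentage points higher from compound 2 to compound 3 (beyond the scatter) and so a weaker effect at the tested concentration in this assay. Exchanging the whole ring group also gives a large step when the new group is 4-bromophenyl: a number 32 percentage points higher from compound 1 to compound 3 (beyond the scatter). Among these three compounds, then, this position is sensitive to which halogen it carries, although nothing available here explains the difference between chloro and bromo.

As far as these compounds go, whether fluoro or iodo at the same place would behave like chloro or like bromo remains open, as does the outcome with a methyl group or an amine. Two halogens are too few to establish a trend.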